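The source may hold more compounds than are shown below. What is called first, only, known or untested is meant among the compounds shown, and "the series" means these compounds.

In an ADME assay on HepG2 cells (Homo sapiens) for cytotoxicity, read by luminescence, CellTiter-Glo and ATP content, with a stated time of 72 h (on this read-out lower numbers stand for an effect already at smaller amounts and higher numbers for an effect only at larger amounts of compound), compound 2 `COc1ccc(F)cc1CNCCCNc1ccnc2cc(C3CCCCC3)ccc12` gives 2290 nM, the smallest of the three numbers measured. Compound 3 `CC(C)(C)c1ccc(-c2ccc3c(NCCCNCc4ccco4)ccnc3c2)cc1` gives 3150 nM, which sits within the scatter of compound 2, while compound 1 `c1ccc(Oc2ccc3c(NCCCNCc4ccco4)ccnc3c2)cc1` gives 15200 nM, a higher number beyond the scatter. The unmeasured compound 4 `COc1ccc(-c2ccc3c(NCCCNCc4cc(F)ccc4OC)ccnc3c2)cc1` differs from compound 2 in one place: 4-methoxyphenyl in place of cyclohexyl on an aromatic carbon. For the measured compounds named here, the only measured step at this position, a 4.8-fold lower number from compound 1 to compound 3 (0.68 log units; beyond the scatter), replaced a phenoxy rather than a cyclohexyl, so it bears on the present change only loosely. Because compound 2 with a cyclohexyl gives 2290 nM and compound 3 with a 4-(tert-butyl)phenyl gives 3150 nM within the scatter of each other, the step from compound 2 to compound 4 is expected to stay within the scatter, a 1.1-fold higher number from compound 2 to compound 4 (0.06 log units; within the scatter). Compound 4 is therefore estimated at 2600 nM, with a range from 1000 nM to 6500 nM.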

Compound 4, half-maximal effective concentration: 5960 nM
Compound 4: middle estimate off by 2.3-fold (0.36 log units), on the low side; the measured number falls inside the stated range.
By their numbers in this assay, from the lowest: compounds 2, 3 and 4 (each within the scatter of the next, the first and the last beyond it); then compound 1.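

Swapping cyclohexyl for 4-methoxyphenyl in this assay gives a 2.6-fold higher number from compound 2 to compound 4 (0.42 log units; beyond the scatter) and so shows that, with the side chain of compound 2 held fixed, the change from a non-aromatic ring to a substituted aromatic ring at this position is not neutral. The earlier step at this position had phenoxy leaving, so it could not show this. Nothing available explains the size or direction of this step. The compounds shown leave open how a small group such as an amine or a carboxylic acid would read at this position. They also leave open whether plain phenyl would fall closer to cyclohexyl or to 4-methoxyphenyl.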